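The source may hold more compounds than are shown below. What is called first, only, known or untested is meant among the compounds shown, and "the series" means these compounds.

Measured in an ADME assay on HEp-2 cells (Homo sapiens) for cytotoxicity; on this read-out higher numbers stand for lower toxicity in this test and lower numbers for higher toxicity in this test:
- Compound 1 `Cc1ccc(NC(=O)[C@@H]2CCCN2S(=O)(=O)c2cccc3cccnc23)cc1`: 31700 nM
- Compound 2 `CCc1ccccc1NC(=O)[C@@H]1CCCN1S(=O)(=O)c1cccc2cccnc12`: > 50000 nM (a limit of the assay, not a number)

In this assay compound 2 has only a limit, > 50000 nM, so its true value is not known. The limit also matters for what follows: the limit of > 50000 nM in this assay, at which 1 of the 2 values shown sits.

The next compound to consider is compound 3 `CC(C)c1ccccc1NC(=O)[C@@H]1CCCN1S(=O)(=O)c1cccc2cccnc12`. It differs from compound 2 by one small change: methyl in place of hydrogen on a saturated chain carbon bound to an aromatic carbon and a saturated chain carbon. In other words, 2-isopropylphenyl replaces 2-ethylphenyl, with methyl in place of hydrogen on a saturated chain carbon bound to an aromatic carbon and a saturated chain carbon.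

Among the measured compounds shown here, only one measured step bears on this change, and it involves a swap of groups on the same amide-type nitrogen: an at least 1.5-fold higher number from compound 1 to compound 2 (0.19 log units; that floor lies within the scatter). That single step gives no size or direction to carry forward, so no change beyond the scatter is expected in this assay. The expected step is a step that the limit leaves unreadable from compound 2 to compound 3, and the assay may again report only a limit. Compound 3 is estimated at 55000 nM, with an expected range from 30000 nM to 100000 nM.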

Compound 3, half-maximal cytotoxic concentration: 29900 nM
The estimate for compound 3 lay 1.8-fold (0.26 log units) above the measured number; the measured number lies below the stated range.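

In this assay, the single methyl that turns 2-ethylphenyl into 2-isopropylphenyl gives an at least 1.6-fold lower number from compound 2 to compound 3 (0.22 log units; that floor lies within the scatter). This is the first time a change to this group can be set against a number on one side, but how far the step really reaches stays unknown because the reading for compound 2 is only a limit of the assay: the limit of > 50000 nM in this assay, at which 1 of the 3 values shown sits.

The comparison with the 4-methylphenyl group gives a 1.1-fold lower number from compound 1 to compound 3 (0.03 log units; within the scatter), so the 2-isopropylphenyl and 4-methylphenyl groups cannot be told apart in this assay.

The compounds shown leave open whether a tert-butyl or a cyclopropyl group in place of the isopropyl would move the number beyond the usual scatter, or whether the number would stay where it is. They also leave open what an amine or a carboxylic acid on the phenyl ring would do to the number in this assay.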